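An Amide Returns on the Amine of Compound 3

The source may hold more compounds than are shown below. What is called first, only, known or untested is meant among the compounds shown, and "the series" means these compounds.

Measured so far:
Compound 1, `Cn1nc2c(=O)n(CC3(O)CCN(Cc4ccc(-c5ccco5)cc4Cl)CC3)cnc2c1-c1ccc(CO)cc1`: 42.5 nM
Compound 2, `CC(=O)NCc1ccc(-c2c3ncn(CC4(O)CCN(Cc5ccc(-c6ccco6)cc5Cl)CC4)c(=O)c3nn2C)cc1`: 46.1 nM
Compound 3, `CCNCc1ccc(-c2c3ncn(CC4(O)CCN(Cc5ccc(-c6ccco6)cc5Cl)CC4)c(=O)c3nn2C)cc1`: 15.2 nM

These values come from an assay on isolated protein for inhibition of ubiquitin carboxyl-terminal hydrolase 7 (Homo sapiens), with stated times of 30 min and 2 h; on this read-out lower numbers stand for stronger inhibition and higher numbers for weaker inhibition. Compound 3 stands lowest of the three, and both other compounds lie beyond the scatter above it: a 2.8-fold lower number from compound 1 to compound 3 (0.45 log units; beyond the scatter) and a 3.0-fold lower number from compound 2 to compound 3 (0.48 log units; beyond the scatter). Compound 4, `Cn1nc2c(=O)n(CC3(O)CCN(Cc4ccc(-c5ccco5)cc4Cl)CC3)cnc2c1-c1ccc(CNC(=O)C(F)(F)F)cc1`, has not yet been measured. It differs from compound 3 in one place: (trifluoromethyl)carbonyl in place of ethyl on an amine nitrogen. For the measured compounds named here, two measured steps bear on this change. In the step of a 3.0-fold lower number from compound 2 to compound 3 (0.48 log units; beyond the scatter) a carbonyl-bearing group on the same amine nitrogen was replaced by ethyl, and the number fell beyond the scatter. Compound 4 runs that change in the opposite direction: a carbonyl group again enters where the ethyl leaves. The step of a 1.1-fold higher number from compound 1 to compound 2 (0.04 log units; within the scatter) shows that a carbonyl-bearing amine at this position and a hydroxy give numbers within the scatter of each other. Compound 4 is therefore expected to move back toward the values of compound 1 and compound 2, a modest upward step, a 3.0-fold higher number from compound 3 to compound 4 (0.47 log units; beyond the scatter). Compound 4 is estimated at 45 nM, within a range of 20 nM to 110 nM.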

Compound 4, half-maximal inhibitory concentration: 2060 nM
Compound 4: middle estimate off by 46-fold (1.66 log units), on the low side; measured number outside the range, above it.
By their numbers in this assay, from the lowest: compound 3; then compounds 1 and 2 (each within the scatter of the next); then compound 4.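

The carbonyl alone does not set the number at this position: in this assay, trifluoromethyl in place of methyl on a carbonyl carbon gives a 45-fold higher number from compound 2 to compound 4 (1.65 log units; beyond the scatter), even though the acetamido and hydroxy groups of compound 2 and compound 1 had stood within the scatter of each other. The new group also sets compound 4 far from the hydroxy compound, with a 48-fold higher number from compound 1 to compound 4 (1.69 log units; beyond the scatter), and from the ethylamino compound, with a 140-fold higher number from compound 3 to compound 4 (2.13 log units; beyond the scatter), so a position that had shown only modest steps can also carry a large one. Nothing given here says what lies behind this large rise.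

The compounds shown leave open whether trifluoromethyl needs the carbonyl to produce this rise: a trifluoroethyl group on the same amine nitrogen would pair directly with compound 3, while a fluoroacetyl or difluoroacetyl group would pair with compound 2 and show whether the number climbs gradually with each added fluorine. On these data alone, a plain primary amine at this position also remains open, as it would show how the unsubstituted nitrogen compares with the ethylamino group of compound 3.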